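The compounds below may be only part of what the source reports. "The series", "measured", "known", "first", "only" and "open" are said of these compounds alone.

Of the compounds shown here, three sharing one core have been measured in an assay on HEK293 cells for displacement of a labelled ligand from Melanocortin receptor 4 (Homo sapiens); on this read-out lower numbers stand for stronger inhibition and higher numbers for weaker inhibition. Compound 3 `CC(C)C[C@H](N)c1cc(C(F)(F)F)ccc1N1CCN(C(=O)CCc2c(Cl)cccc2Cl)CC1` gives 2600 nM, the highest of the three numbers, although its distance from the others lies within the scatter: compound 2 `CC(C)C[C@H](N)c1cc(C(F)(F)F)ccc1N1CCN(C(=O)CCc2cccc(C(F)(F)F)c2)CC1` gives 2200 nM and compound 1 `CC(C)C[C@H](N)c1cc(C(F)(F)F)ccc1N1CCN(C(=O)CCc2ccccc2Cl)CC1` gives 1700 nM. The steps of a 1.3-fold higher number from compound 1 to compound 2 (0.11 log units; within the scatter), a 1.5-fold higher number from compound 1 to compound 3 (0.18 log units; within the scatter) and a 1.2-fold higher number from compound 2 to compound 3 (0.07 log units; within the scatter) all stay within the scatter. Compound 4 `CC(C)C[C@H](N)c1cc(C(F)(F)F)ccc1N1CCN(C(=O)CCc2cccs2)CC1` arises from compound 3 by thiophen-2-yl in place of 2,6-dichlorophenyl on a saturated chain carbon, two bonds along the chain from a carbonyl carbon. For the measured compounds named here, no measured step concerns a thiophene; the three aryl changes already seen shifted this assay by no more than the scatter, so compound 4 is expected to show little change, an expected step of a 1.3-fold lower number from compound 3 to compound 4 (0.11 log units; within the scatter). Compound 4 is therefore estimated at 2000 nM, with a range from 800 nM to 5000 nM.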

Compound 4, inhibition constant: 4600 nM
Beside the measured number, compound 4's estimate is 2.3-fold (0.36 log units) below it; the range from low to high includes it.
By their numbers in this assay, from the lowest: compounds 1, 2, 3 and 4 (each within the scatter of the next, the first and the last beyond it).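

In this assay, for the compounds shown here, thiophen-2-yl is the first group at this position to take the number beyond the scatter, with a 2.1-fold higher number from compound 2 to compound 4 (0.32 log units; beyond the scatter) and a 2.7-fold higher number from compound 1 to compound 4 (0.43 log units; beyond the scatter) both modest. The change from 2,6-dichlorophenyl stays within the scatter, at a 1.8-fold higher number from compound 3 to compound 4 (0.25 log units; within the scatter), so compound 3 goes against any clean separation of thiophen-2-yl from the phenyl groups. No evidence on hand bears on this shift. From the compounds shown here alone, it remains open whether the sulfur-containing ring itself matters or whether unsubstituted phenyl would behave alike. Also open, going by these compounds, is how a pyridin-2-yl ring, a ring-bound amine or a longer chain would read here.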